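The source may hold more compounds than are shown below. What is called first, only, known or untested is meant among the compounds shown, and "the series" means these compounds.

Of the compounds shown here, two have been measured so far in an assay on cells for inhibition of Amine oxidase [flavin-containing] B (Homo sapiens), read by fluorescence and Amplex Red, with a stated time of 15 min; on this read-out higher numbers stand for weaker inhibition and lower numbers for stronger inhibition. Compound 1, `Cc1ccc2cc(-c3ccc(Br)nn3)c(=O)oc2c1`, gives 750 nM in this assay. Compound 2, `Cc1cccc2cc(-c3ccc(Br)nn3)c(=O)oc12`, gives 2640 nM in this assay. Of these two numbers, compound 2 holds the higher one. The gap between compound 2 and compound 1 lies beyond the usual scatter of repeated measurements, and compound 2 is the weaker inhibitor of the pair.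

Compound 3, `COc1cccc2cc(-c3ccc(Br)nn3)c(=O)oc12`, has not yet been measured. It differs from compound 2 in one place: methoxy in place of methyl on an aromatic carbon. Among the compounds with values here, no measured pair shows what this particular change does, so the expected step from compound 2 to compound 3 in this assay, a 1.1-fold lower number from compound 2 to compound 3 (0.02 log units; within the scatter), is taken as small and within the usual scatter, in no clear direction. On that basis compound 3 is estimated at 2500 nM in this assay, with a plausible range from 900 nM to 7000 nM.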

Compound 3, half-maximal inhibitory concentration: 12900 nM
Estimate against measurement, compound 3: 5.2-fold (0.71 log units) below; measured number above the stated range.
By their numbers in this assay, from the lowest: compound 1; then compound 2; then compound 3.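

In this assay, exchanging methyl for methoxy on this aromatic carbon is not a neutral swap: the change gives a 4.9-fold higher number from compound 2 to compound 3 (0.69 log units; beyond the scatter) and so weakens inhibition. This position therefore responds to the group it carries, even though the exchange adds only one heavy atom, an oxygen, and one hydrogen-bond acceptor. Nothing among the available data explains the loss.

The compounds shown leave open whether inhibition at this carbon would change with a bare hydrogen, a chlorine, an amine or a longer chain such as ethoxy, and so whether methyl is a good group here or merely better than methoxy. They also leave open whether the same exchange on another carbon of the shared core would weaken inhibition too.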